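Moving the Chlorine on the Sulfonyl Phenyl Ring

This account rests on a few compounds, and the source may have more. Where it says the series, first, only, none or still open, it means among the compounds named here.

Compound 2 `O=C(c1ccc(-c2cccc(NS(=O)(=O)c3cccc(Cl)c3)c2)s1)c1cc(F)c(F)c(O)c1F` gives 0.7 h in an ADME assay on S9 fraction from liver (Homo sapiens) for metabolic stability, using NADPH, in the presence of a further agent that is not named here; on this read-out lower numbers stand for a shorter-lived compound and higher numbers for a longer-lived compound. Within the data shown here, only one other compound has been measured: compound 1 `Cc1ccc(S(=O)(=O)Nc2cccc(-c3ccc(C(=O)c4cc(F)c(F)c(O)c4F)s3)c2)cc1` gives 0.533 h, and the step of a 1.3-fold higher number from compound 1 to compound 2 (0.12 log units; within the scatter) shows that the two values sit within the scatter of each other. Compound 3 `O=C(c1ccc(-c2cccc(NS(=O)(=O)c3ccc(Cl)cc3)c2)s1)c1cc(F)c(F)c(O)c1F` differs from compound 2 by 4-chlorophenyl in place of 3-chlorophenyl on a sulfonyl sulfur. Among the measured compounds shown here, no measured step compares these two chlorine positions directly, and the single measured step, which exchanged a whole aryl group, was small. Compound 3 is therefore expected to show no shift beyond the scatter, a step of a 1.1-fold lower number from compound 2 to compound 3 (0.03 log units; within the scatter), with an estimated 0.65 h between 0.35 h and 1.3 h.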

Compound 3, half-life: 0.667 h
Estimate against measurement, compound 3: 1.0-fold (0.01 log units) below; the range from low to high includes it.
By their numbers in this assay, from the lowest: compounds 1, 3 and 2 (each within the scatter of the next).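

The chlorine can sit in either place named here, 3-chlorophenyl or 4-chlorophenyl on the sulfonyl sulfur, with a step of a 1.0-fold lower number from compound 2 to compound 3 (0.02 log units; within the scatter) in this assay. Chloro in place of methyl on an aromatic carbon also stays within the scatter, at a 1.3-fold higher number from compound 1 to compound 3 (0.10 log units; within the scatter). No measurement at hand offers an explanation for either result. Still open, as far as these compounds go, is whether an amine or a carboxylic acid on the phenyl ring attached to the sulfonyl sulfur would give a step beyond the scatter.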